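The source may report more compounds than this note shows. Statements on the series, on what has been measured and on what is new or still open speak of the compounds shown alone.

The measured compounds:

Compound 1, `O=c1ccoc(/C=C/c2ccccc2)c1`: 711 uM
Compound 2, `COc1ccc(/C=C/c2cc(=O)cco2)cc1`: 710 uM
Compound 3, `COc1cc(/C=C/C2CC=CC(=O)N2)cc(OC)c1`: 212 uM

In an ADME assay on HaCaT cells (Homo sapiens) for inhibition, read by sulforhodamine B assay, with a stated time of 48 h (a lower number here means a stronger inhibitor of growth, a higher number a weaker inhibitor of growth), compound 1 gives 711 uM. Compound 2 carries the change methoxy in place of hydrogen on an aromatic carbon and in this assay compound 2 gives 710 uM; the step is a 1.0-fold lower number from compound 1 to compound 2 (0.00 log units; within the scatter), so the two numbers cannot be told apart. Compound 3 rests on a different core, and the difference between the two cores is not broken down here; in this assay compound 3 gives 212 uM, which stands beyond the scatter from both compound 1 and compound 2.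

Compound 4, `COc1cc(/C=C/C2CC=CC(=O)N2)cc(OC)c1OC`, has not been measured. It differs from compound 3 by methoxy in place of hydrogen on an aromatic carbon. Among the measured compounds shown here, this is the same kind of change as the one from compound 1 to compound 2, though not the same: in compound 4 the entering methoxy sits ortho to two methoxy groups and para to a group of 9 heavy atoms, whereas in compound 2 it sits only para to a group of 9 heavy atoms. For the measured compounds named here, the only precedent, a 1.0-fold lower number from compound 1 to compound 2 (0.00 log units; within the scatter), lay within the scatter, so the step from compound 3 to compound 4 is expected to be small as well, namely a 1.0-fold lower number from compound 3 to compound 4 (0.00 log units; within the scatter), because the value of compound 3, 212 uM, is taken as the anchor. Compound 4 is thus estimated at 210 uM, expected to fall between 90 uM and 480 uM, with the wider crowding around the new group leaving the direction uncertain.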

Compound 4, concentration for growth inhibition (reported as GI): > 864 uM
Compound 4: a limit, no number; the forecaster's own chance of this, stated with the estimate: 5%; middle value at least 4.1-fold (0.61 log units) away from the limit.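

In this assay compound 4 gives > 864 uM, which is a limit of the assay and not a number: the limit of > 864 uM in this assay, at which 1 of the 4 values shown sits. Even so, methoxy in place of hydrogen on an aromatic carbon gives an at least 4.0-fold higher number from compound 3 to compound 4 (0.61 log units; beyond the scatter), so the change does not carry over unchanged from the core of compound 1 to the core of compound 3: the same change on two cores in this assay, a 1.0-fold lower number (0.00 log units; within the scatter) from compound 1 to compound 2 and an at least 4.0-fold higher number (0.61 log units; beyond the scatter) from compound 3 to compound 4, at least 4.0-fold (0.61 log units) apart, beyond the scatter of two such steps. This shows only that the outcome of the change is not the same in these two pairs, and it does not show how large the step from compound 3 really is, nor whether the core itself accounts for the difference, since the entering methoxy in compound 4 sits ortho to two methoxy groups and para to a group of 9 heavy atoms, whereas in compound 2 it sits only para to such a group.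

The compounds shown leave open whether three methoxy groups on the core of compound 1 would also raise the number, and whether a single methoxy on the core of compound 3 would leave it in place. Also open, going by these compounds, is how a hydroxy group, a fluorine atom or an ethoxy group at the same place on compound 3 would read in this assay.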